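The source may hold more compounds than are shown below. What is called first, only, known or untested is meant among the compounds shown, and "the series" means these compounds.

In a functional assay on MCF7 cells (Homo sapiens) for inhibition, read by radiometric assay and XTT assay (a higher number here means a weaker inhibitor, a lower number a stronger inhibitor), compound 3 (`CCCCCCCC[C@@]1(C)SC(=O)C=C1OCC(=O)OCC`) gives 35.3 ug/mL and sits within the scatter of the other two measured compounds. Compound 2 (`CCCCCC[C@@]1(C)SC(=O)C=C1OCC(=O)OCC`) gives 39.6 ug/mL in the same assay. Compound 4 (`CCCCCCCC[C@@]1(C)SC(=O)C=C1OC(=O)OC`) differs from compound 3 by one exchange (methoxycarbonyl in place of (ethoxycarbonyl)methyl on an oxygen on an unsaturated carbon): methoxycarbonyl in place of (ethoxycarbonyl)methyl on an oxygen on an unsaturated carbon. For the measured compounds named here, no measured step covers this exchange directly. Going by the values given here, the one measured step is a 1.1-fold lower number from compound 2 to compound 3 (0.05 log units; within the scatter) and it sits on the chain. Compound 1 (`CCCCCCCC[C@@]1(C)SC(O)=C(C)C1=O`) lacks the (ethoxycarbonyl)methyl group and gives 48 ug/mL with no gap to compound 3 beyond the scatter. No step beyond the scatter is therefore expected in this assay and the expected step is a 1.1-fold higher number from compound 3 to compound 4 (0.03 log units; within the scatter) only. For compound 4 the estimate is 38 ug/mL with an expected range from 20 ug/mL to 70 ug/mL in this read-out.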

Compound 4, half-maximal inhibitory concentration: 21.6 ug/mL
The estimate for compound 4 lay 1.8-fold (0.25 log units) above the measured number, and the stated range covers the measured number.
By their numbers in this assay, from the lowest: compounds 4, 3, 2 and 1 (each within the scatter of the next, the first and the last beyond it).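

At the oxygen on an unsaturated carbon, methoxycarbonyl in place of (ethoxycarbonyl)methyl gives a 1.6-fold lower number from compound 3 to compound 4 (0.21 log units; within the scatter) in this assay. For the compounds shown here, this is the first reading at this position, and a substituent with fewer heavy atoms, the same count of hydrogen-bond acceptors and a carbonyl directly on the oxygen leaves the read-out within the scatter. No available evidence explains this result.

From the compounds shown here alone, whether an amine or a carboxylic acid on this oxygen would give a step beyond the scatter remains open. Also open, going by these compounds, is whether methoxycarbonyl behaves the same way on the shorter chain of compound 2.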